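Removing a bromo group on a shared core

A few compounds are considered here, and "the series" means these few. Any claim that something is new, unique, unknown or untested is made for them only; others in the source may bear on it.

Measured so far:
Compound 1, `Cc1ccc(C2=NN(c3nc(-c4ccc(Br)cc4)cs3)C(c3cccs3)C2)cc1`, gives 18400 nM in a functional assay on WM 266-4 cells (Homo sapiens) for antiproliferative activity, read by MTT assay, with a stated time of 48 h; on this read-out higher numbers stand for weaker inhibition and lower numbers for stronger inhibition.
Compound 2, `Cc1ccc(C2=NN(c3nc(-c4ccccc4)cs3)C(c3cccs3)C2)cc1`, gives 7520 nM in this assay.
Compound 3, `Clc1ccc(C2=NN(c3nc(-c4ccc(Br)cc4)cs3)C(c3cccs3)C2)cc1`, gives 1450 nM in this assay.

Compound 4, `Clc1ccc(C2=NN(c3nc(-c4ccccc4)cs3)C(c3cccs3)C2)cc1`, has not yet been measured. It differs from compound 3 in one place: hydrogen in place of bromo on an aromatic carbon. The same change has already been made once, from compound 1 to compound 2: hydrogen in place of bromo on an aromatic carbon. The two sites are described in the same words, so this is the same change made on a different core. That earlier step gave a 2.4-fold lower number from compound 1 to compound 2 (0.39 log units; beyond the scatter), a modest move toward stronger inhibition.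

The cores of the two pairs are not identical. Compound 3 differs from compound 1 as follows: chloro in place of methyl on an aromatic carbon. That single change produced a 13-fold lower number from compound 1 to compound 3 (1.10 log units; beyond the scatter), and compound 3 gives the lowest number of the three measured compounds, beyond the scatter from both others.

For compound 4 the step from compound 3 is expected to be a 2.2-fold lower number from compound 3 to compound 4 (0.35 log units; beyond the scatter). Among the compounds with values here, this expectation rests on compound 1 and compound 2, because a 2.4-fold lower number from compound 1 to compound 2 (0.39 log units; beyond the scatter) is the only measured example of this change, and with one example its transfer to a different core is uncertain. Compound 4 is therefore estimated at 650 nM, with a plausible range from 250 nM to 1800 nM in this assay.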

Compound 4, half-maximal inhibitory concentration: 2190 nM
Beside the measured number, compound 4's estimate is 3.4-fold (0.53 log units) below it, and the stated range ends below it.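

With the chloro group in place, removing the bromo gives a 1.5-fold higher number from compound 3 to compound 4 (0.18 log units; within the scatter) in this assay, so compound 3 and compound 4 cannot be told apart, and this result does not match the step measured on the core of compound 1: the same change on two cores in this assay, a 2.4-fold lower number (0.39 log units; beyond the scatter) from compound 1 to compound 2 and a 1.5-fold higher number (0.18 log units; within the scatter) from compound 3 to compound 4, 3.7-fold (0.57 log units) apart, beyond the scatter of two such steps. Seen from the other side, chloro in place of methyl lowers the number on both cores, with a 3.4-fold lower number from compound 2 to compound 4 (0.54 log units; beyond the scatter) when no bromo is present, but the size of this step also depends on the core: the same change on two cores in this assay, a 13-fold lower number (1.10 log units; beyond the scatter) from compound 1 to compound 3 and a 3.4-fold lower number (0.54 log units; beyond the scatter) from compound 2 to compound 4, 3.7-fold (0.57 log units) apart, beyond the scatter of two such steps. Both comparisons use the same four compounds, so together they show one fact: the effects of the two changes do not simply add, and the bromo step measured on one core did not carry over to the other, though this single pair of cores cannot show why or which behaviour is more typical of the series.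

The compounds shown leave open how a fluoro group, a methoxy group or an amine would behave in place of the bromo on each core. They also leave open whether the same mismatch between the two steps would appear with an ethyl group in place of the methyl or chloro.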